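This account rests on a few compounds, and the source may have more. Where it says the series, first, only, none or still open, it means among the compounds named here.

Compound 1 `CCN1CCN(c2ccc(S(=O)(=O)Oc3ccc(OC)c(OC)c3)cc2)C1=O`, compound 2 `CCN1CCN(c2ccc(S(=O)(=O)Oc3ccc(OC)cc3)cc2)C1=O` and compound 3 `CCCN1CCN(c2ccc(S(=O)(=O)Oc3cccc(OC)c3)cc2)C1=O` have all been measured in a functional assay on M21 cells (Homo sapiens) for antiproliferative activity, read by sulforhodamine B assay, with a stated time of 48 h (on this read-out higher numbers stand for weaker inhibition and lower numbers for stronger inhibition), while compound 4 `CCCN1CCN(c2ccc(S(=O)(=O)Oc3cc(OC)cc(OC)c3)cc2)C1=O` has not. In this assay compound 1 gives 35000 nM, compound 2 gives 26000 nM and compound 3 gives 10000 nM. Compound 2 and compound 1 differ in one place, (methoxy in place of hydrogen on an aromatic carbon), and the result of that change is a 1.3-fold higher number from compound 2 to compound 1 (0.13 log units; within the scatter). The difference between the core of compound 2 and the core of compound 3 is not broken down here; compound 3 simply shows the lowest number of the three, with its steps to both others beyond the scatter. Compound 4 arises from compound 3 by the same kind of change, (methoxy in place of hydrogen on an aromatic carbon), though the surroundings differ: in compound 1 the entering group sits ortho to a methoxy group and meta to a large group, whereas in compound 4 it sits meta to a large group and meta to a methoxy group. Because the earlier instance gave a 1.3-fold higher number from compound 2 to compound 1 (0.13 log units; within the scatter), a similarly small step is expected, a 1.3-fold higher number from compound 3 to compound 4 (0.11 log units; within the scatter). Compound 4 is therefore estimated at 13000 nM, likely between 5000 nM and 32000 nM.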

Compound 4, half-maximal inhibitory concentration: 33000 nM
Compound 4: middle estimate off by 2.5-fold (0.40 log units), on the low side, outside the stated range (above it).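

Replacing hydrogen with methoxy on an aromatic carbon gives, in this assay, a 3.3-fold higher number from compound 3 to compound 4 (0.52 log units; beyond the scatter). Set beside the earlier instance of this change, the new step cannot be told apart from it: the same change on two cores in this assay, a 1.3-fold higher number (0.13 log units; within the scatter) from compound 2 to compound 1 and a 3.3-fold higher number (0.52 log units; beyond the scatter) from compound 3 to compound 4, 2.5-fold (0.39 log units) apart, within the scatter of two such steps. The two results are therefore compatible with the change carrying over from one core to the other, yet only the new step lies beyond the scatter on its own, and two pairs neither fix a size for the change nor separate the effect of the core from that of the different surroundings on the aromatic ring.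

The compounds shown leave open whether another group in the same place, such as a hydroxyl, a fluorine or an amine, would give a step of similar size. They also leave open whether the step would persist on a core bearing a longer chain.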